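Swapping the Terminal Aryl Ring of a Shared Core

The compounds below may be only part of what the source reports. "The series", "measured", "known", "first", "only" and "open" are said of these compounds alone.

Compound 1 `O=C(Nc1cccc(CNc2nccnc2Cl)c1)Nc1ccccc1Cl`: 7130 nM
Compound 2 `O=C(Nc1cccc(CNc2nccnc2Cl)c1)Nc1ccccc1F`: 6440 nM
Compound 3 `CC(C)(C)c1ccc(NC(=O)Nc2cccc(CNc3nccnc3Cl)c2)cc1`: 4820 nM

These three compounds share one core and differ only in the aromatic ring attached to the amide-type nitrogen. In a functional assay on MGC-803 cells (Homo sapiens) for antiproliferative activity, read by MTT assay, with a stated time of 48 h (on this read-out higher numbers stand for weaker inhibition and lower numbers for stronger inhibition), compound 2 gives 6440 nM, the second highest of the three numbers, and it sits within the scatter of both compound 1 and compound 3. Within the data shown here, the one single-site step measured so far, a 1.1-fold lower number from compound 1 to compound 2 (0.04 log units; within the scatter), also stays within the scatter. Compound 4 `COc1ccc(NC(=O)Nc2cccc(CNc3nccnc3Cl)c2)cc1` has not yet been measured; it differs from compound 2 by 4-methoxyphenyl in place of 2-fluorophenyl on an amide-type nitrogen. Among the measured compounds shown here, no measured step covers this exact change, but all three measured values lie close together, so no step beyond the scatter is expected: a 1.2-fold lower number from compound 2 to compound 4 (0.07 log units; within the scatter). Compound 4 is therefore estimated at 5500 nM, between 2500 nM and 12000 nM.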

Compound 4, half-maximal inhibitory concentration: 9240 nM
Beside the measured number, compound 4's estimate is 1.7-fold (0.23 log units) below it, and the stated range covers the measured number.
By their numbers in this assay, from the lowest: compounds 3, 2, 1 and 4 (each within the scatter of the next).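

Putting 4-methoxyphenyl on the amide-type nitrogen gives a 1.4-fold higher number from compound 2 to compound 4 (0.16 log units; within the scatter) and a 1.3-fold higher number from compound 1 to compound 4 (0.11 log units; within the scatter) in this assay while methoxy in place of tert-butyl on an aromatic carbon gives a 1.9-fold higher number from compound 3 to compound 4 (0.28 log units; within the scatter) so every new step stays within the scatter. This position has therefore now carried a group with a hydrogen-bond acceptor without any step beyond the scatter. Nothing available explains the size of these steps.

Still open, on these data alone, is whether a ring carrying an amine or a carboxylic acid, or a longer chain in place of the ring, would give a step beyond the scatter.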